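The source may hold more compounds than are shown below. What is called first, only, known or untested is meant among the compounds shown, and "the series" means these compounds.

Measured so far in a functional assay on NCI-H226 cells (Homo sapiens) for inhibition, read by sulforhodamine B assay, with a stated time of 48 h, tested at 10 uM; a lower number here means less inhibition, a higher number more inhibition at the concentration tested (going by the name of the read-out):
Compound 1 `COc1ccc(-c2cn3ccnc3c(-c3ccc4ncn(C5CCCCC5)c4c3)n2)cc1`: 35.9%
Compound 2 `c1cn2cc(-c3ccsc3)nc(-c3ccc4ncn(C5CCCCC5)c4c3)c2n1`: 6.34%
Compound 3 `Clc1ccc(-c2cn3ccnc3c(-c3ccc4ncn(C5CCCCC5)c4c3)n2)cc1`: 19.4%

Compound 3 holds the second highest of the three numbers. Its neighbours are set out by the two steps that reach it: a number 13.1 percentage points higher from compound 2 to compound 3 (beyond the scatter) and a number 16.5 percentage points lower from compound 1 to compound 3 (beyond the scatter), both beyond the scatter, so compound 3 sits clearly between compound 2 and compound 1.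

The next compound, compound 4 `COc1ccccc1-c1cn2ccnc2c(-c2ccc3ncn(C4CCCCC4)c3c2)n1`, is not yet measured. It differs from compound 3 by a single exchange: 2-methoxyphenyl in place of 4-chlorophenyl on an aromatic carbon

For the measured compounds named here, only one measured step touches this exchange. The step from compound 1 to compound 3 swapped methoxy for chloro on the same aromatic carbon and gave a number 16.5 percentage points lower from compound 1 to compound 3 (beyond the scatter); the step to compound 4 reverses that swap in kind, but puts the methoxy on a different carbon of the ring, for which no measurement exists. The step of a number 29.6 percentage points lower from compound 1 to compound 2 (beyond the scatter) and the step of a number 13.1 percentage points higher from compound 2 to compound 3 (beyond the scatter) concern thiophen-3-yl and give no direct guidance. A rise of modest size is therefore expected because a number 16.5 percentage points lower from compound 1 to compound 3 (beyond the scatter) was measured for the methoxy in another position, and a full return to that earlier level is not assumed. The expected step is a number 8.6 percentage points higher from compound 3 to compound 4 (within the scatter). Compound 4 is accordingly estimated at 28%, within a range from 12% to 45%.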

Compound 4, a percentage reported as inhibition, at one concentration (the size of the read-out at that concentration, not a potency): 25.7%
Compound 4: the middle estimate sits 2.3 percentage points above what was measured; the range from low to high includes it.
By their numbers in this assay, from the lowest: compound 2; then compounds 3 and 4 (each within the scatter of the next); then compound 1.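

In this assay, for the compounds shown here, the exchange to 2-methoxyphenyl from 4-methoxyphenyl gives a number 10.2 percentage points lower from compound 1 to compound 4 (beyond the scatter) and is the first reading of one substituent at two places on the phenyl ring, so at this position of the shared core the place of the methoxy on that ring counts, not only its presence. Against 4-chlorophenyl the same group gives a number 6.3 percentage points higher from compound 3 to compound 4 (within the scatter) and the two cannot be told apart here, while against thiophen-3-yl it gives a number 19.4 percentage points higher from compound 2 to compound 4 (beyond the scatter) and all three compounds with a substituted phenyl, compound 1, compound 3 and compound 4, now stand above compound 2. No measurement in hand accounts for any of these differences.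

Still open, on these data alone, is how an unsubstituted phenyl, or a phenyl carrying an amine or a carboxylic acid, would stand against these four compounds in this assay and whether a chloro group shows the same dependence on its place on the ring as the methoxy. All of these readings come from a single concentration, so they leave the potency of the series undefined and show only the size of the inhibition at that concentration.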